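Methoxy to hydroxy on a series that sits at limits

The compounds below may be only part of what the source reports. "The series", "measured", "known", "first", "only" and "open" are said of these compounds alone.

Compound 1 `COc1cc(-c2nn(-c3cccc(NC(=O)c4cccc(C(F)(F)F)c4)c3)cc2-c2ccncc2)ccc1Cl` gives in a functional assay on A549 cells (Homo sapiens) for inhibition, read by sulforhodamine B assay, with a stated time of 48 h (a lower number here means that less compound is tolerated, a higher number that more compound is tolerated), only the limit > 50000 nM.
Compound 2 `COc1cc(-c2nn(-c3cccc(NC(=O)Nc4ccc(Cl)c(C(F)(F)F)c4)c3)cc2-c2ccncc2)ccc1Cl` gives in this assay only the limit > 32500 nM.
Compound 3 `COc1cc(-c2nn(-c3cccc(NC(=O)c4ccccc4)c3)cc2-c2ccncc2)ccc1Cl` gives in this assay only the limit > 100000 nM.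

Every value shown is a limit of the assay, not a measured number, so compound 2 cannot be placed above or below its neighbours. The three steps between them, a step that the two limits leave unreadable from compound 1 to compound 2, a step that the two limits leave unreadable from compound 1 to compound 3 and a step that the two limits leave unreadable from compound 2 to compound 3, are all unreadable, which the three limits (the limit of > 100000 nM in this assay, at which 1 of the 3 values shown sits), the limit of > 32500 nM in this assay, at which 1 of the 3 values shown sits, and the limit of > 50000 nM in this assay, at which 1 of the 3 values shown sits, make plain: each compound simply tolerated all of the dose that was tried.

Compound 4 `O=C(Nc1cccc(-n2cc(-c3ccncc3)c(-c3ccc(Cl)c(O)c3)n2)c1)Nc1ccc(Cl)c(C(F)(F)F)c1` differs from compound 2 by a single change, (hydrogen in place of methyl on an oxygen on an aromatic ring). Within the data shown here, no measured step in this set touches that position, so nothing here tells in which direction it should move.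

Among the measured compounds shown here, the only guide is that compound 2 and its two relatives all sit at limits. Compound 4 is therefore expected to behave much like them, and the step that the limit leaves unreadable from compound 2 to compound 4 is estimated to stay within the scatter. Compound 4 is estimated at 40000 nM, between 10000 nM and 100000 nM, most likely again reported as a limit.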

Compound 4, concentration lethal to 50% of the cells: > 32500 nM
Compound 4 ended at the assay's limit (the forecaster's own chance of this, stated with the estimate: 70%); the middle value does not contradict the limit.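

Compound 2 and compound 4 both stop at a limit of the assay, so the step from methoxy to hydroxy cannot be read: the limit of > 32500 nM in this assay, at which 2 of the 4 values shown sit.

The four compounds shown leave open whether swapping methoxy for hydroxy changes the result at all in this assay, since each gives only a limit and none gives a measured number.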